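A few compounds are considered here, and "the series" means these few. Any claim that something is new, unique, unknown or untested is made for them only; others in the source may bear on it.

Among the measured compounds shown here, in a functional assay (aorta) for inhibition, with Rattus norvegicus as the target (on this read-out higher numbers stand for an effect only at larger amounts of compound and lower numbers for an effect already at smaller amounts), compound 1 (`O=C1C(Nc2ccc(F)cc2)=CC(=O)c2ncccc21`) gives 541 nM as the higher of the two numbers measured so far. For the measured compounds named here, compound 2 (`O=C1C(Nc2ccc(F)c(F)c2)=CC(=O)c2ncccc21`) gives 251 nM and is the only other measured compound. Compound 3 (`O=C1C(Nc2ccc(Br)cc2)=CC(=O)c2ncccc21`) is still unmeasured and differs from compound 1 at one place (bromo in place of fluoro on an aromatic carbon) with bromo in place of fluoro on an aromatic carbon. Going by the values given here, one measured step bears on this only loosely. It is a 2.2-fold lower number from compound 1 to compound 2 (0.33 log units; beyond the scatter) and it is modest, with fluoro in place of hydrogen on an aromatic carbon, whereas compound 3 loses the fluoro and carries bromo instead. With so little to go on, the expected change is a 1.4-fold lower number from compound 1 to compound 3 (0.13 log units; within the scatter) and it is small, leaning toward a lower number, with no step beyond the scatter expected. The estimate for compound 3 is 400 nM and the expected range of 150 nM to 950 nM is wide.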

Compound 3, half-maximal effective concentration: 302 nM
The estimate for compound 3 lay 1.3-fold (0.12 log units) above the measured number; measured number inside the range.
By their numbers in this assay, from the lowest: compounds 2, 3 and 1 (each within the scatter of the next, the first and the last beyond it).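

Going from fluoro to bromo at this place, on the aromatic ring and para to a large group, gives a 1.8-fold lower number from compound 1 to compound 3 (0.25 log units; within the scatter), so in this assay the two halogens cannot be told apart. Among the compounds shown here, the earlier pair kept fluoro here in both compounds, so this is the first view of what the place accepts: bromo serves as well as fluoro, with no difference beyond the scatter. Nothing at hand explains why the two groups read alike.

Going by these compounds, only these two halogens are seen at this place, so it remains open whether an amine, a methoxy group or a carboxylic acid would be accepted too. Also open, on these data alone, is how a plain hydrogen here would read, which would show whether a halogen at this place matters at all.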